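Cyclopentyl for 3-fluorophenyl: compound 3 to compound 4

This account rests on a few compounds, and the source may have more. Where it says the series, first, only, none or still open, it means among the compounds named here.

Measured so far in a toxicity assay on THP-1 cells (Homo sapiens) for inhibition; a higher number here means that more compound is tolerated, a lower number that less compound is tolerated (every value is a limit of the assay, not a number):
- compound 1 `CCCC(=O)Nc1ncc(-c2ccc(OC)cc2)n1C` gives > 100000 nM as a limit
- compound 2 `COc1ccc(-c2cnc(NC(=O)c3cnco3)n2C)cc1` gives > 100000 nM as a limit
- compound 3 `COc1ccc(-c2cnc(NC(=O)c3cccc(F)c3)n2C)cc1` gives > 100000 nM as a limit

Compound 3 stands at the limit > 100000 nM in this assay and has no number of its own. Among the compounds with values here, the series so far offers only the limit of > 100000 nM in this assay, at which 3 of the 3 values shown sit, and no value that can be ranked.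

Compound 4 `COc1ccc(-c2cnc(NC(=O)C3CCCC3)n2C)cc1` has cyclopentyl in place of 3-fluorophenyl on a carbonyl carbon. The measured steps that bear on this change sit at the same carbonyl carbon. They are a step that the two limits leave unreadable from compound 1 to compound 3 and a step that the two limits leave unreadable from compound 2 to compound 3 and also a step that the two limits leave unreadable from compound 1 to compound 2 and none of them has a size that can be read. Propyl, 1,3-oxazol-5-yl and 3-fluorophenyl all end at the same limit, which gives no direction for a new group.

The expected step is a number no higher from compound 3 to compound 4 (the limit leaves the size open) and nothing beyond the scatter is expected. Compound 4 is estimated at 100000 nM with a range of 40000 nM to 200000 nM and is expected to be reported only as a limit.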

Compound 4, half-maximal cytotoxic concentration: > 100000 nM
Compound 4 ended at the assay's limit; the forecaster's own chance of this, stated with the estimate: 85%; the middle value sits exactly at the limit.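

In this assay compound 4 gives > 100000 nM, a limit of the assay and not a number. The steps from compound 1, compound 2 and compound 3 to compound 4 cannot be read. The compounds shown leave open which group on the carbonyl carbon, if any, would give a value that can be ranked, because the series rests at a single limit: the limit of > 100000 nM in this assay, at which 4 of the 4 values shown sit.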